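The source may report more compounds than this note shows. Statements on the series, on what has been measured and on what is new or still open speak of the compounds shown alone.

Measured compounds:
Compound 1, `CC(C)(C)c1ccc(CNC(=O)NCCCCl)cc1`, 17000 nM
Compound 2, `CCCCCc1cccc(NC(=O)NCCCCl)c1`, 26000 nM

In a functional assay on MCF7 cells (Homo sapiens) for antiproliferative activity, with a stated time of 48 h (on this read-out higher numbers stand for weaker inhibition and lower numbers for stronger inhibition), compound 1 gives 17000 nM. In the same assay compound 2 gives 26000 nM, the higher of the two numbers, though its gap to compound 1 lies within the scatter, so the two compounds cannot be told apart on these data. Compound 3, `CCCCC(O)c1cccc(NC(=O)NCCCCl)c1`, has not yet been measured in this assay. It differs from compound 2 in one place: hydroxy in place of hydrogen on a saturated chain carbon bound to an aromatic carbon and a saturated chain carbon. Among the measured compounds shown here, no step between measured compounds is known for this kind of change, so nothing in the numbers so far points to a direction. The account therefore expects no step beyond the scatter, and the estimated step from compound 2 to compound 3 is a 1.2-fold higher number from compound 2 to compound 3 (0.06 log units; within the scatter). Compound 3 is expected to give about 30000 nM in this assay, with a likely range from 10000 nM to 90000 nM.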

Compound 3, half-maximal inhibitory concentration: > 100000 nM
Compound 3: only a limit was reported; the forecaster's own chance of this, stated with the estimate: 20%; at least 3.3-fold (0.52 log units) between middle value and limit.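

Hydroxy on a saturated chain carbon bound to an aromatic carbon and a saturated chain carbon is the first single change here with a readable step: in this assay, going from pentyl to 1-hydroxypentyl gives an at least 3.8-fold higher number from compound 2 to compound 3 (0.58 log units; beyond the scatter). This place on the chain is therefore not indifferent to substitution, and here the change goes with weaker inhibition, which the earlier pair, differing in more than one place, could not show. The size of the step is only a lower bound, as compound 3 stands at a limit of the assay and not at a number: the limit of > 100000 nM in this assay, at which 1 of the 3 values shown sits.

From the compounds shown here alone, how far compound 3 lies past that limit stays open. So does whether a methoxy, an amine or a ketone carbonyl at the same carbon would go the same way as hydroxy, and the compounds shown give no cause for the step.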